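This account rests on a few compounds, and the source may have more. Where it says the series, first, only, none or still open, it means among the compounds named here.

Three measured compounds share one core. In an assay on HEK293 cells for positive allosteric modulation of metabotropic glutamate receptor 2 (Rattus norvegicus), read by thallium flux, with a stated time of 2.5 min (on this read-out lower numbers stand for smaller maximal responses and higher numbers for larger maximal responses), compound 1 `Cc1cc(C(=O)O)ccc1OCCCCOc1ccc(C(=O)CC(C)C)c(O)c1C` gives 83.9%. Compound 2 `COc1cc(C(=O)O)ccc1OCCCCOc1ccc(C(=O)CC(C)C)c(O)c1C` gives 85.7% in this assay. Compound 3 `Cc1c(OCCCCOc2ccc(C(=O)O)cc2)ccc(C(=O)CC(C)C)c1O` gives 88% in this assay. The three steps between them, a number 1.8 percentage points higher from compound 1 to compound 2 (within the scatter), a number 4.1 percentage points higher from compound 1 to compound 3 (within the scatter) and a number 2.3 percentage points higher from compound 2 to compound 3 (within the scatter), all stay within the scatter, so these three compounds cannot be told apart on this read-out. Compound 2 stands second of the three numbers, with compound 1 the nearer neighbour and compound 3 the further one, both within the scatter.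

Compound 4 `CCC(=O)c1ccc(OCCCCOc2ccc(C(=O)O)cc2OC)c(C)c1O` differs from compound 2 in one place: methyl in place of isopropyl on a saturated chain carbon bound to a carbonyl carbon. Going by the values given here, none of the measured steps touches this part of the molecule; all three swap a group on an aromatic carbon elsewhere in the core, and none alters the chain bound to the carbonyl carbon. Among the compounds with values here, there is therefore no measured step that bears directly on this change, and the only guide is that every change tried so far left the largest response within the scatter. The expectation is that the step of a number 1.7 percentage points lower from compound 2 to compound 4 (within the scatter) will again fall within the scatter. Compound 4 is estimated at 84%, with a range from 68% to 96%.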

Compound 4, largest response reached (reported as percent of maximum), in percent of the reference or control that the assay uses: 86.5%
Compound 4: middle estimate off by 2.5 percentage points, on the low side, and the stated range covers the measured number.
By their numbers in this assay, from the lowest: compounds 1, 2, 4 and 3 (each within the scatter of the next).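

Going by these compounds alone, this is the first result that touches the chain bound to the carbonyl carbon, since every earlier step swapped a group on an aromatic carbon. In this assay, within the data shown here, methyl in place of isopropyl at this place gives a number 0.8 percentage points higher from compound 2 to compound 4 (within the scatter) and so leaves the two compounds indistinguishable on this read-out: the isobutylcarbonyl group of the one and the propanoyl group of the other are both compatible with a large maximal response, at least on the core of compound 2. No supporting measurement is available to explain this result.

The compounds shown leave open how far this chain can be varied, for example whether a longer chain such as hexyl, a ring such as cyclopropyl or phenyl, or an amine on the chain would still give a response in the same range. They also leave open whether the swap matters for the concentration needed to reach the response, since the largest response alone does not reveal that concentration.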